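Four analogues on a shared core: cytotoxicity notes

The source may report more compounds than this note shows. Statements on the series, on what has been measured and on what is new or still open speak of the compounds shown alone.

Measured so far:
compound 1 `COc1cc2ncnc(Nc3ccc(F)c(Cl)c3)c2cc1OCCCSc1nc2ccccc2o1`: 4050 nM
compound 2 `COc1cc2ncnc(Nc3cccc(C(F)(F)F)c3)c2cc1OCCCSc1nc2ccccc2o1`: 4030 nM
compound 3 `CCCCc1nc(Cl)c(C=O)n1CCCOc1cc2c(Nc3ccc(F)c(Cl)c3)ncnc2cc1OC`: 5020 nM

All three were run in a functional assay on MCF7 cells (Homo sapiens) for cytotoxicity, read by MTT assay, with a stated time of 24 h; a lower number here means a stronger inhibitor, a higher number a weaker inhibitor. Compound 1 and compound 2 share one core; compound 3 and the unmeasured compound 4 `CCCCc1nc(Cl)c(C=O)n1CCCOc1cc2c(Nc3cccc(C(F)(F)F)c3)ncnc2cc1OC` share another. The two cores differ by 2-butyl-4-chloro-5-formyl-1H-imidazol-1-yl in place of (1,3-benzoxazol-2-yl)sulfanyl on a saturated chain carbon, three bonds along the chain from an oxygen on an aromatic ring, and in this assay that exchange gave a 1.2-fold higher number from compound 1 to compound 3 (0.09 log units; within the scatter). Compound 3 and compound 2 were not compared directly; their two values lie within the usual scatter of each other.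

The change of interest is 3-(trifluoromethyl)phenyl in place of 3-chloro-4-fluorophenyl on a nitrogen on an aromatic ring. In this assay it gave a 1.0-fold lower number from compound 1 to compound 2 (0.00 log units; within the scatter), a flat result. The same change occurs a second time, as 3-(trifluoromethyl)phenyl in place of 3-chloro-4-fluorophenyl on a nitrogen on an aromatic ring; the place reads identically in both pairs, so this is the same change on a different core.

With the first occurrence flat, the step from compound 3 to compound 4 in this assay is expected to be about as small, a 1.0-fold lower number from compound 3 to compound 4 (0.00 log units; within the scatter), because a 1.0-fold lower number from compound 1 to compound 2 (0.00 log units; within the scatter) showed no movement. Compound 4 is therefore estimated at 5000 nM, with a likely range of 2500 nM to 10000 nM.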

Compound 4, half-maximal inhibitory concentration: 3510 nM
Beside the measured number, compound 4's estimate is 1.4-fold (0.15 log units) above it, and the stated range covers the measured number.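

In this assay the exchange of 3-chloro-4-fluorophenyl for 3-(trifluoromethyl)phenyl gives a 1.4-fold lower number from compound 3 to compound 4 (0.16 log units; within the scatter), and the two cores agree on this step: the same change on two cores in this assay, a 1.0-fold lower number (0.00 log units; within the scatter) from compound 1 to compound 2 and a 1.4-fold lower number (0.16 log units; within the scatter) from compound 3 to compound 4, 1.4-fold (0.15 log units) apart, within the scatter of two such steps

The exchange of (1,3-benzoxazol-2-yl)sulfanyl for 2-butyl-4-chloro-5-formyl-1H-imidazol-1-yl, read with 3-(trifluoromethyl)phenyl in place, gives a 1.1-fold lower number from compound 2 to compound 4 (0.06 log units; within the scatter), and it agrees with its counterpart on the other aryl group: the same change on two cores in this assay, a 1.2-fold higher number (0.09 log units; within the scatter) from compound 1 to compound 3 and a 1.1-fold lower number (0.06 log units; within the scatter) from compound 2 to compound 4, 1.4-fold (0.15 log units) apart, within the scatter of two such steps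

Within this four-compound square, the aryl exchange therefore carries from one core to the other as a step inside the scatter, but this shows only that neither core separates the two aryl groups, not that a step large enough to read would transfer in the same way.

Going by these compounds, it remains open whether any group on the nitrogen, such as a phenyl carrying a carboxylic acid or an amine, would give a step beyond the scatter. On these data alone, a longer chain to the oxygen on the aromatic ring is likewise open, as is whether any such step would hold on both cores.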